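From fluoro to trifluoromethyl on compound 1

This account rests on a few compounds, and the source may have more. Where it says the series, first, only, none or still open, it means among the compounds named here.

Compound 1 (`O=[N+]([O-])c1ccc(S(=O)(=O)n2c(-c3cn(-c4ccccc4)nc3-c3ccc(F)cc3)nc3ccccc32)cc1`) gives 189000 nM in an ADME assay on HEK-293T cells (Homo sapiens) for cytotoxicity, read by MTT assay, with a stated time of 24 h (on this read-out lower numbers stand for higher toxicity in this test and higher numbers for lower toxicity in this test), and stands highest of the two compounds measured, ahead of compound 2 (`O=S(=O)(c1ccc(Cl)cc1)n1c(-c2cn(-c3ccccc3)nc2-c2ccc(F)cc2)nc2ccccc21`) with 93100 nM as its number. For the measured compounds named here, the only measured step, a 2.0-fold lower number from compound 1 to compound 2 (0.31 log units; beyond the scatter) for chloro in place of nitro on an aromatic carbon, lies elsewhere on the molecule and guides size alone. Compound 3 (`O=[N+]([O-])c1ccc(S(=O)(=O)n2c(-c3cn(-c4ccccc4)nc3-c3ccc(C(F)(F)F)cc3)nc3ccccc32)cc1`) instead has trifluoromethyl in place of fluoro on an aromatic carbon. A small drop in this assay is expected, estimated as a 1.6-fold lower number from compound 1 to compound 3 (0.20 log units; within the scatter) with wide uncertainty. Compound 3 is expected near 120000 nM (estimated range 55000 nM to 250000 nM).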

Compound 3, half-maximal cytotoxic concentration: 163000 nM
The estimate for compound 3 lay 1.4-fold (0.13 log units) below the measured number, and the stated range covers the measured number.
By their numbers in this assay, from the lowest: compounds 2, 3 and 1 (each within the scatter of the next, the first and the last beyond it).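

At this position, in this assay, trifluoromethyl in place of fluoro gives a 1.2-fold lower number from compound 1 to compound 3 (0.06 log units; within the scatter) and so stays within the usual scatter, even though the group grows from one heavy atom to four. For the compounds shown here, this is the first view of how this spot on the shared core responds to a change, as the earlier step concerned a different place. No measurement shown accounts for this result. Still open, going by these compounds, is how an amine or a carboxylic acid would read at this position. Also open, on these data alone, is whether trifluoromethyl would behave the same way with chloro in place of nitro.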